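This account rests on a few compounds, and the source may have more. Where it says the series, first, only, none or still open, it means among the compounds named here.

Of the compounds shown here, three of one family have been tested in a functional assay on PC-3 cells (Homo sapiens) for cytotoxicity, read by sulforhodamine B assay, tested at 10 uM; a higher number here means more inhibition at the concentration tested (going by the name of the read-out), a lower number less inhibition. Compound 1 `CC(=O)OC[C@H]1O[C@@H](n2cc(-c3cn(Cc4ccccc4)nn3)c(=O)[nH]c2=O)C[C@@H]1OC(C)=O` gives 92.1% in this assay. Compound 2 `O=c1[nH]c(=O)n([C@H]2C[C@H](O)[C@@H](CO)O2)cc1-c1cn(Cc2ccccc2)nn1`, which carries the same core and the same benzyl group but lacks the two acetyl groups, gives 92.1% in this assay, and compound 3 `CCCCCc1cc(-c2cn([C@H]3C[C@H](OC(C)=O)[C@@H](COC(C)=O)O3)c(=O)[nH]c2=O)on1`, in which a different ring carrying a pentyl chain stands on the core, gives 93.9% in this assay. All three numbers sit within the usual scatter of one another, so compound 1 stands level with compound 2 and with compound 3, and none of the three can be set apart from the others.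

The step to be followed leads from compound 1 to compound 4 `CC(=O)OC[C@H]1O[C@@H](n2cc(-c3cn(Cc4ccc(C(C)C)cc4)nn3)c(=O)[nH]c2=O)C[C@@H]1OC(C)=O`. The change is isopropyl in place of hydrogen on an aromatic carbon. Going by the values given here, no pair of measured compounds shows this particular change, so its effect has to be judged from the near-identical numbers of compounds 1, 2 and 3 alone. Because compound 2 gives 92.1% and compound 3 gives 93.9% despite their structural differences from compound 1, the step is expected to be a number 2.1 percentage points lower from compound 1 to compound 4 (within the scatter), which would be none beyond the scatter. Compound 4 is therefore estimated to give 90% in this assay, with a range from 76% to 97%.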

Compound 4, a percentage reported as inhibition, at one concentration (the size of the read-out at that concentration, not a potency): 91.3%
Beside the measured number, compound 4's estimate is 1.3 percentage points below it, and the stated range covers the measured number.
By their numbers in this assay, from the lowest: compounds 4, 1, 2 and 3 (each within the scatter of the next).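

Within this assay the swap of phenyl to 4-isopropylphenyl gives a number 0.8 percentage points lower from compound 1 to compound 4 (within the scatter) when the isopropyl group enters on the aromatic carbon para to a large group. Going by these compounds alone, this shows that the benzyl group of compound 1 can carry isopropyl at this position with no difference that stands out from the usual scatter, something the earlier compounds, which differ from one another in more than one place, could not show. Nothing measured here offers an explanation for this result.

Going by these compounds, it stays open whether an amine, a carboxylic acid or a longer chain such as pentyl at this same position would also leave the read-out level. Also open, on these data alone, is whether compounds this close at one concentration would still read alike at lower concentrations.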